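The compounds below may be only part of what the source reports. "The series", "measured", "known", "first", "only" and "open" are said of these compounds alone.

Working notes on the series

Compound 3 `Cc1cc(=O)n(-c2cccc(F)c2)nc1C(=O)Nc1ccc(Oc2ncnc3c2ccn3C)c(F)c1` stands at the higher of the two numbers given in a functional assay on PC-3 cells (Homo sapiens) for cytotoxicity, read by MTT assay, with a stated time of 72 h; a lower number here means a stronger inhibitor, a higher number a weaker inhibitor: compound 3 gives 8990 nM. Its nearest neighbour is compound 1 `Cc1cc(=O)n(-c2cccc(F)c2)nc1C(=O)Nc1ccc(Oc2ncnc3[nH]ccc23)c(F)c1`, which in this assay gives 6680 nM; the step of a 1.3-fold higher number from compound 1 to compound 3 (0.13 log units; within the scatter) is small and the two are not separable. Compound 2 `Cc1cc(=O)n(-c2ccccc2OC(F)(F)F)nc1C(=O)Nc1ccc(Oc2ncnc3c2ccn3C)c(F)c1` reaches only a limit of this assay, > 60000 nM. That limit, (the limit of > 60000 nM in this assay, at which 1 of the 3 values shown sits), is what the step of an at least 6.6-fold lower number from compound 2 to compound 3 (0.82 log units; beyond the scatter) rests on.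

Compound 4 `Cc1cc(=O)n(-c2ccccc2C(F)(F)F)nc1C(=O)Nc1ccc(Oc2ncnc3c2ccn3C)c(F)c1` differs from compound 3 by 2-(trifluoromethyl)phenyl in place of 3-fluorophenyl on an aromatic nitrogen. Of the measured steps, only an at least 6.6-fold lower number from compound 2 to compound 3 (0.82 log units; beyond the scatter) bears on this change, since it likewise exchanges the 3-fluorophenyl on an aromatic nitrogen for a phenyl carrying a fluorinated group in the 2-position, there 2-(trifluoromethoxy)phenyl. Read in the opposite direction, a rise of the number well beyond the scatter is expected, with a fair chance that only a limit is reported. The expected step is a 5.6-fold higher number from compound 3 to compound 4 (0.75 log units; beyond the scatter). For compound 4 the estimate in this assay is 50000 nM, with a range from 15000 nM to 150000 nM.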

Compound 4, half-maximal inhibitory concentration: 25900 nM
The estimate for compound 4 lay 1.9-fold (0.29 log units) above the measured number; the range from low to high includes it.
By their numbers in this assay, from the lowest: compounds 1 and 3 (each within the scatter of the next); then compound 4. At a limit, above all of these: compound 2.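

With 2-(trifluoromethyl)phenyl on the aromatic nitrogen, this assay returns a number rather than a limit, so the loss on leaving 3-fluorophenyl can now be sized: a 2.9-fold higher number from compound 3 to compound 4 (0.46 log units; beyond the scatter). The group on the aromatic carbon of that phenyl ring also counts, since trifluoromethyl in place of trifluoromethoxy gives an at least 2.3-fold lower number from compound 2 to compound 4 (0.36 log units; beyond the scatter). Compound 2 stands at a limit, and that step is therefore a bound and not a size: the limit of > 60000 nM in this assay, at which 1 of the 4 values shown sits.

Between compound 3 and compound 4 both the group and its place on the phenyl ring change, and the compounds shown do not separate the two, which 2-fluorophenyl or 3-(trifluoromethyl)phenyl could do. Also open, as far as these compounds go, is how a phenyl ring carrying an amine or a carboxylic acid would read in this assay.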